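A methoxy-to-hydrogen step on the cinnamoyl pyrazole series

The source may hold more compounds than are shown below. What is called first, only, known or untested is meant among the compounds shown, and "the series" means these compounds.

Compound 1 `COc1ccc(-c2cc(/C=C/C(=O)c3ccc(N)cc3)[nH]n2)cc1`: -30%
Compound 2 `COc1cc(-c2cc(/C=C/C(=O)c3ccc(N)cc3)[nH]n2)cc(OC)c1OC`: -24%
Compound 3 `COc1ccc(C(=O)/C=C/c2cc(-c3cc(OC)c(OC)c(OC)c3)n[nH]2)cc1`: -64%

In a functional assay on MCF7 cells (Homo sapiens) for cytotoxicity, read by sulforhodamine B assay, with a stated time of 48 h, tested at 10 uM (a higher number here means a weaker effect of the compound at the concentration tested, a lower number a stronger effect), compound 2 stands at the top of the three numbers shown; compound 1 lies within the usual scatter of it, whereas the step of a number 40 percentage points lower from compound 2 to compound 3 (beyond the scatter) is large. Compound 4 `COc1ccc(-c2cc(/C=C/C(=O)c3ccc(N)cc3)[nH]n2)cc1OC` differs from compound 2 as follows: hydrogen in place of methoxy on an aromatic carbon. Among the measured compounds shown here, no measured step matches this change. The one step shown, a number 40 percentage points lower from compound 2 to compound 3 (beyond the scatter), concerns a different group and does not bear on it. For the measured compounds named here, compound 1 and compound 2 differ in more than one place, so they show no single step, but their values sit within the scatter of each other. Compound 4 is therefore expected to show no step beyond the scatter, a number 3 percentage points lower from compound 2 to compound 4 (within the scatter). The value of compound 4 in this assay is estimated at -27%, within -45% to -9%.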

Compound 4, a percentage reported as activity, at one concentration (the size of the read-out at that concentration, not a potency): -6%
Compound 4: middle estimate off by 21 percentage points, on the low side, outside the stated range (above it).
By their numbers in this assay, from the lowest: compound 3; then compounds 1 and 2 (each within the scatter of the next); then compound 4.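

In this assay hydrogen in place of methoxy on an aromatic carbon is no silent change: it gives a number 18 percentage points higher from compound 2 to compound 4 (beyond the scatter) and so weakens the effect. Methoxy in place of hydrogen on the same ring gives a number 24 percentage points higher from compound 1 to compound 4 (beyond the scatter) and leaves compound 4 the weaker of that pair too, so the effect does not simply follow the gain or loss of a methoxy group on this ring. No evidence bears on the cause of either step.

As far as these compounds go, whether a hydroxyl or an ethoxy group at this carbon would restore the effect stays open. So does whether the same loss of methoxy weakens the effect when methoxy replaces amino, as in compound 3.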